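A few compounds are considered here, and "the series" means these few. Any claim that something is new, unique, unknown or untested is made for them only; others in the source may bear on it.

Measured compounds:
- compound 1, `Oc1cccc(-c2cc(-c3cccnc3)nc(-c3cccc(Cl)c3)c2)c1`: "not determined" (no result reported) in a functional assay on HCT-15 cells (Homo sapiens) for cytotoxicity, read by CCK-8 assay and cell counting, with a stated time of 2 days; on this read-out lower numbers stand for stronger inhibition and higher numbers for weaker inhibition
- compound 2, `Oc1cccc(-c2cc(-c3ccncc3)nc(-c3cccc(Cl)c3)c2)c1`: "not determined" (no result reported) in this assay
- compound 3, `Oc1cccc(-c2cc(-c3cccc(Cl)c3)nc(-c3ccco3)c2)c1`: 2460 nM

Three compounds share a core that carries a 3-hydroxyphenyl group, a chlorophenyl group and a third aromatic ring. Compound 2 stands without a number in this assay, and compound 1 is a further entry without a number, so neither gives a reference point. Within the data shown here, the only measured value comes from compound 3, which in this assay gives 2460 nM.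

Compound 4, `Oc1cccc(-c2cc(-c3ccncc3)nc(-c3ccc(Cl)cc3)c2)c1`, differs from compound 2 in one place: 4-chlorophenyl in place of 3-chlorophenyl on an aromatic carbon. Among the measured compounds shown here, since compound 2 has no measured value, no step between measured compounds can be stated, and the direction and size of this change cannot be read from the data. The expectation for compound 4 therefore rests on compound 3 alone, whose 2460 nM suggests micromolar potency within this series. On that basis compound 4 is expected to give roughly 3000 nM in this assay, with a wide range from 500 nM to 20000 nM.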

Compound 4, half-maximal inhibitory concentration: 2630 nM
For compound 4 the middle estimate is 1.1-fold (0.06 log units) above the measured one; measured number inside the range.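

In this assay compound 4 gives 2630 nM but compound 2 has no number, so no new step can be read between them. From the compounds shown here alone, whether 4-chlorophenyl in place of 3-chlorophenyl changes the value stays open, and no other data here bear on this result.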